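The source may report more compounds than this note shows. Statements on the series, on what has been measured and on what is new or still open speak of the compounds shown alone.

Of the compounds shown here, three sharing one core have been measured. Compound 1 `Oc1cccc(-c2ccc3ccccc3c2)c1` gives 12% in an assay for binding affinity to 17-beta-hydroxysteroid dehydrogenase type 2 (Homo sapiens), with a stated time of 20 min, tested at 1 uM; on this read-out lower numbers stand for less inhibition and higher numbers for more inhibition at the one concentration tested (going by the name of the read-out). Among the compounds with values here, compound 2 `Oc1cccc(-c2ccc3c(O)cccc3c2)c1` gives 32% in this assay, and a number 20 percentage points higher from compound 1 to compound 2 (beyond the scatter) is the only single-change step measured so far. Compound 3 `COc1ccc(-c2ccc3c(O)cccc3c2)cc1` gives 20% in this assay, the second highest of the three numbers, within the scatter of compound 1 and beyond it below compound 2.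

Compound 4 `O=[N+]([O-])c1ccc(-c2ccc3c(O)cccc3c2)cc1` differs from compound 3 by nitro in place of methoxy on an aromatic carbon. Within the data shown here, no measured step swaps one substituent for another on this ring, so the hydroxy-for-hydrogen step does not bear directly on this change. The expected step of a number 2 percentage points higher from compound 3 to compound 4 (within the scatter) therefore stays within the scatter, in no clear direction. Compound 4 is estimated at 22%, with a range from 5% to 42%.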

Compound 4, a percentage reported as inhibition, at one concentration (the size of the read-out at that concentration, not a potency): 13%
The estimate for compound 4 lay 9 percentage points above the measured number, within the range that was stated.
By their numbers in this assay, from the lowest: compounds 1, 4 and 3 (each within the scatter of the next); then compound 2.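

In this assay, nitro in place of methoxy on the aromatic carbon para to a large group gives a number 7 percentage points lower from compound 3 to compound 4 (within the scatter). Within the data shown here, this is the first measured swap of one substituent for another on this ring, and it does not separate the two groups, although nitro has more heavy atoms and hydrogen-bond acceptors than methoxy. Nothing available explains this result.

Going by these compounds, it remains open whether an amine or a carboxylic acid at this place would give a number beyond the scatter of compound 3. On these data alone, the effect of removing the substituent from this place also remains open.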